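This account rests on a few compounds, and the source may have more. Where it says the series, first, only, none or still open, it means among the compounds named here.

Working notes on the series.

In an ADME assay on MDCK cells (Canis lupus familiaris) for cytotoxicity, read by microscopy, with a stated time of 48 h (on this read-out lower numbers stand for higher toxicity in this test and higher numbers for lower toxicity in this test), compound 2 `C[C@H]1[C@H](NCc2cccs2)C[C@H]2C[C@@H]1C2(C)C` gives 25000 nM. Among the compounds with values here, on the two numbers so far compound 2 has the lowest number; its nearest neighbour is compound 1 `C[C@H]1[C@H](NCc2ccc(Br)s2)C[C@H]2C[C@@H]1C2(C)C`, which in this assay gives 43000 nM. Within the data shown here, the one measured step, a 1.7-fold lower number from compound 1 to compound 2 (0.24 log units; within the scatter), concerns removal of bromo from the aromatic carbon and is within the scatter, so no ordering between compound 1 and compound 2 can be read from it.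

Compound 3 `Cc1n[nH]cc1CN[C@@H]1C[C@H]2C[C@@H]([C@H]1C)C2(C)C` differs from compound 2 in one place: 3-methyl-1H-pyrazol-4-yl in place of thiophen-2-yl on a saturated chain carbon bound to an amine nitrogen. The saturated bicyclic core and the amine linkage are kept.

Among the measured compounds shown here, no measured step covers an exchange of the whole aromatic ring at this position; the only step available, a 1.7-fold lower number from compound 1 to compound 2 (0.24 log units; within the scatter), touches a substituent on that ring and stays within the scatter. There is therefore no basis for expecting a step in this assay beyond the scatter in either direction, and the uncertainty is set wide to reflect that the change is larger than anything measured.

Compound 3 is estimated to give 30000 nM in this assay, with a range from 10000 nM to 100000 nM. This estimate means a step of a 1.2-fold higher number from compound 2 to compound 3 (0.08 log units; within the scatter).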

Compound 3, minimum cytotoxic concentration: > 100000 nM
Compound 3 gave a limit, no number (the forecaster's own chance of this, stated with the estimate: 15%); middle value at least 3.3-fold (0.52 log units) from the limit.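

At this position, exchanging the whole aromatic ring in this assay gives an at least 4.0-fold higher number from compound 2 to compound 3 (0.60 log units; beyond the scatter), whereas removing bromo from the ring gave only a 1.7-fold lower number from compound 1 to compound 2 (0.24 log units; within the scatter). Set against the 5-bromothiophen-2-yl group, the same exchange gives an at least 2.3-fold higher number from compound 1 to compound 3 (0.36 log units; beyond the scatter), so the 3-methyl-1H-pyrazol-4-yl group is the one group shown that separates from the others on this read-out, in the direction of lower toxicity in this test. The true size of both steps stays open at the upper end, since compound 3 reads only as a limit of the assay and not as a number: the limit of > 100000 nM in this assay, at which 1 of the 3 values shown sits.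

Going by these compounds, whether the step follows the five-membered ring with 2 hetero atoms or the methyl group on it remains open, and an unsubstituted 1H-pyrazol-4-yl group on the same chain carbon would separate the two. A phenyl or a pyridin-3-yl ring in that place would show whether any nitrogen-bearing ring gives a step of this kind or whether it is particular to the pyrazole.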